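Compound 3: 1-hydroxycyclobutyl replaces 2,2,2-trifluoro-1-hydroxyethyl

This account rests on a few compounds, and the source may have more. Where it says the series, first, only, none or still open, it means among the compounds named here.

For the measured compounds named here, in an in vitro ADME assay on microsomes from Gut (Homo sapiens) for metabolic stability, using NADPH (a lower number here means slower removal, a higher number faster removal of the compound), compound 2 `N#Cc1ccc2c(c1)cc(C(=O)NCCC(O)C(F)(F)F)n2Cc1cccc(OC(F)(F)F)c1` gives 26 mL.min-1.g-1 as the only true number so far. Compound 1 `CC(O)CCNC(=O)c1cc2cc(C#N)ccc2n1Cc1cccc(OC(F)(F)F)c1` stands at < 6 mL.min-1.g-1 and this is a limit of the assay. Compound 3 `N#Cc1ccc2c(c1)cc(C(=O)NCCC1(O)CCC1)n2Cc1cccc(OC(F)(F)F)c1` carries 1-hydroxycyclobutyl in place of 2,2,2-trifluoro-1-hydroxyethyl on a saturated chain carbon, two bonds along the chain from an amide-type nitrogen. Going by the values given here, the one measured step, trifluoromethyl in place of methyl, runs (an at least 4.3-fold higher number from compound 1 to compound 2 (0.63 log units; beyond the scatter)) and lies beyond the scatter, so with trifluoromethyl leaving again a lower number is expected for compound 3 in this assay as well. The expected size is modest, an estimated 1.9-fold lower number from compound 2 to compound 3 (0.27 log units; within the scatter) for this change. Compound 3 is estimated at 14 mL.min-1.g-1 with a range from 6 mL.min-1.g-1 to 40 mL.min-1.g-1 as the expected span.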

Compound 3, intrinsic clearance in microsomes: < 6 mL.min-1.g-1
Compound 3: no number, only a limit; the forecaster's own chance of this, stated with the estimate: 20%; at least 2.3-fold (0.36 log units) between middle value and limit.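

In this assay, the change to 1-hydroxycyclobutyl brings an at least 4.3-fold lower number from compound 2 to compound 3 (0.63 log units; beyond the scatter). A second group without trifluoromethyl thus gives a low reading at this place, so among the three compounds shown only compound 2, with 2,2,2-trifluoro-1-hydroxyethyl, stands clear of the limit. Compound 1 and compound 3 both give only a limit of the assay, so the step between them cannot be read: the limit of < 6 mL.min-1.g-1 in this assay, at which 2 of the 3 values shown sit.

On these data alone, whether an amine, a carboxylic acid or a longer chain at this place would also stay at that limit in this assay remains open.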